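The source may hold more compounds than are shown below. What is called first, only, known or untested is meant among the compounds shown, and "the series" means these compounds.

The series shares one core, varied only in the aryl group on the oxygen on the aromatic ring. Compound 1 `CCc1nn(C)c(CO/N=C/c2c(C)nn(C)c2Oc2ccc(F)cc2)c1Cl` carries a 4-fluorophenyl there; in a functional assay on SMMC-7721 cells (Homo sapiens) for inhibition, read by MTT assay, with a stated time of 72 h, tested at 25 uM (a lower number here means less inhibition, a higher number more inhibition at the concentration tested (going by the name of the read-out)), compound 1 gives < 80%, which is a limit of the assay and not a number. Compound 2 `CCc1nn(C)c(CO/N=C/c2c(C)nn(C)c2Oc2ccccc2F)c1Cl` carries a 2-fluorophenyl; in this assay compound 2 gives < 80%, again a limit. Compound 3 `CCc1nn(C)c(CO/N=C/c2c(C)nn(C)c2Oc2ccccc2Cl)c1Cl` carries a 2-chlorophenyl; in this assay compound 3 gives < 80%, also a limit. All three sit at the same limit, as noted in the limit of < 80% in this assay, at which 3 of the 3 values shown sit, so the steps a step that the two limits leave unreadable from compound 1 to compound 2, a step that the two limits leave unreadable from compound 1 to compound 3 and a step that the two limits leave unreadable from compound 2 to compound 3 cannot be read in size or direction.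

Compound 4 `CCc1nn(C)c(CO/N=C/c2c(C)nn(C)c2Oc2ccc(I)cc2)c1Cl` differs from compound 3 as follows: 4-iodophenyl in place of 2-chlorophenyl on an oxygen on an aromatic ring. For the measured compounds named here, no measured step in the set separates one aryl variant from another, so nothing points to a change beyond the scatter. The estimate for compound 4 is therefore a step that the limit leaves unreadable from compound 3 to compound 4 that stays near the limit, and compound 4 is expected to give 40% in this assay, within the range 5% to 80%.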

Compound 4, a percentage reported as inhibition, at one concentration (the size of the read-out at that concentration, not a potency): < 80%
Compound 4: no number, only a limit (the forecaster's own chance of this, stated with the estimate: 80%); the middle value lies beyond the limit too.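

Compound 4 also gives only a limit, so its steps from compound 1, compound 2 and compound 3 cannot be read in size or direction: the limit of < 80% in this assay, at which 4 of the 4 values shown sit.

The compounds shown leave open whether these aryl variants differ at all in this assay.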